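Removing a prenyl-type group on a weak indole series

The source may report more compounds than this note shows. Statements on the series, on what has been measured and on what is new or still open speak of the compounds shown alone.

The series shares a core in which compound 1 `C=CC(C)(C)c1[nH]c2c(CC=C(C)C)cccc2c1/C=C1\NC(=O)[C@H](C)NC1=O` carries a 3-methylbut-2-en-1-yl group on the aromatic ring. In a functional assay (on this read-out higher numbers stand for weaker inhibition and lower numbers for stronger inhibition), compound 1 gives 86000 nM. Compound 2 `C=CC(C)(C)c1[nH]c2ccccc2c1/C=C1\NC(=O)[C@H](C)NC1=O` differs from it by hydrogen in place of 3-methylbut-2-en-1-yl on an aromatic carbon, and in this assay compound 2 gives 103000 nM; the step is a 1.2-fold higher number from compound 1 to compound 2 (0.08 log units; within the scatter).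

Compound 3 `C=CC(C)(C)c1[nH]c2ccc(CC=C(C)C)cc2c1/C=c1\[nH]c(=O)c(=C)[nH]c1=O` has a different core; the difference between the two cores is not broken down here. In this assay compound 3 gives 60000 nM, which lies within the scatter of both compound 1 and compound 2.

Compound 4 `C=CC(C)(C)c1[nH]c2ccccc2c1/C=c1\[nH]c(=O)c(=C)[nH]c1=O` has not been measured. It differs from compound 3 by hydrogen in place of 3-methylbut-2-en-1-yl on an aromatic carbon. This is the same kind of change as from compound 1 to compound 2, but the place differs: in compound 3 the group sits meta to a fused ring and para to a fused ring, whereas in compound 1 it sits ortho to a fused ring and meta to a fused ring. Because the earlier step was a 1.2-fold higher number from compound 1 to compound 2 (0.08 log units; within the scatter), the expected step is a 1.2-fold higher number from compound 3 to compound 4 (0.07 log units; within the scatter). In this assay compound 4 is expected to give about 70000 nM, within 35000 nM to 140000 nM.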

Compound 4, half-maximal inhibitory concentration: 65000 nM
For compound 4 the middle estimate is 1.1-fold (0.03 log units) above the measured one, within the range that was stated.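

In this assay, hydrogen in place of 3-methylbut-2-en-1-yl on the core of compound 3 gives a 1.1-fold higher number from compound 3 to compound 4 (0.03 log units; within the scatter). The change therefore behaves alike on both cores, even though the group sits at a different place on each: the same change on two cores in this assay, a 1.2-fold higher number (0.08 log units; within the scatter) from compound 1 to compound 2 and a 1.1-fold higher number (0.03 log units; within the scatter) from compound 3 to compound 4, 1.1-fold (0.04 log units) apart, within the scatter of two such steps

This shows that, for these two pairs, removing the group produces no step beyond the scatter, but it does not show that the change would carry over in the same way to other cores. Nor does it show that the two places are interchangeable, as each core is seen with the group at only one place, and all the numbers remain weak.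

The compounds shown leave open whether an amine, a carboxylic acid or a longer chain at these places would move the number beyond the scatter. They also leave open how each core would respond with the 3-methylbut-2-en-1-yl group at the place it occupies on the other.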